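Thiophen-2-yl for thiophen-3-yl in a cytotoxicity series

The source may report more compounds than this note shows. Statements on the series, on what has been measured and on what is new or still open speak of the compounds shown alone.

Measured compounds:
compound 1 `Oc1ccc(-c2cc(-c3ccc(Cl)cc3)nc(-c3cccs3)c2)cc1` gives 4520 nM in an ADME assay on HEK293 cells (Homo sapiens) for cytotoxicity, read by CCK-8 assay and cell counting, with a stated time of 2 days; a higher number here means a weaker inhibitor, a lower number a stronger inhibitor
compound 2 `Oc1ccc(-c2cc(-c3ccc(Cl)cc3)nc(-c3ccsc3)c2)cc1` gives 4860 nM in this assay
compound 3 `Oc1cccc(-c2cc(-c3ccsc3)nc(-c3cccc(Cl)c3)c2)c1` gives 3180 nM in this assay

The three values lie within the scatter of one another, so no order among them is drawn. The difference between the core of compound 3 and that of compound 2 is not broken down here.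

Compound 4 `Oc1cccc(-c2cc(-c3cccc(Cl)c3)nc(-c3cccs3)c2)c1` is not yet measured. It differs from compound 3 by thiophen-2-yl in place of thiophen-3-yl on an aromatic carbon. The same kind of change has been measured once, from compound 2 to compound 1, as thiophen-2-yl in place of thiophen-3-yl on an aromatic carbon, where the step was a 1.1-fold lower number from compound 2 to compound 1 (0.03 log units; within the scatter). The surroundings are not identical: in the measured pair the place is meta to a 4-chlorophenyl group and meta to a 4-hydroxyphenyl group, whereas in the new pair it is meta to a 3-chlorophenyl group and meta to a 3-hydroxyphenyl group. It is therefore the same kind of change, not the same change.

For compound 4 a step of a 1.1-fold lower number from compound 3 to compound 4 (0.03 log units; within the scatter) is expected, resting on the measured step of a 1.1-fold lower number from compound 2 to compound 1 (0.03 log units; within the scatter) and on compound 3 at 3180 nM. Compound 4 is accordingly estimated at 3000 nM, with a likely range from 1500 nM to 6000 nM.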

Compound 4, half-maximal inhibitory concentration: 3150 nM
For compound 4 the middle estimate is 1.1-fold (0.02 log units) below the measured one, within the range that was stated.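

In this assay, thiophen-2-yl in place of thiophen-3-yl gives a 1.0-fold lower number from compound 3 to compound 4 (0.00 log units; within the scatter). Set beside the earlier pair, the change carries from one core to the other with no difference beyond the scatter: the same change on two cores in this assay, a 1.1-fold lower number (0.03 log units; within the scatter) from compound 2 to compound 1 and a 1.0-fold lower number (0.00 log units; within the scatter) from compound 3 to compound 4, 1.1-fold (0.03 log units) apart, within the scatter of two such steps Both steps lie within the scatter, so this shows only that the two thiophene attachments are not told apart on these two cores; it does not show that the change would stay as small on a core carrying other groups.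

Open, going by these compounds, is whether an amine or a carboxylic acid at the thiophene's place would give a step beyond the scatter. Also open, on these data alone, is what replacing the chloro or hydroxy substituents with a methoxy group would do.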